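The compounds below may be only part of what the source reports. "The series", "measured", "known", "first", "only" and "open" are said of these compounds alone.

Measured so far:
Compound 1, `CC(C)N1CCN(Cc2csc(N)c2C(=O)c2ccc(Cl)cc2)CC1`: 0%
Compound 2, `Nc1scc(CN2CCN(c3cccc4ccccc34)CC2)c1C(=O)c1ccc(Cl)cc1`: 0%

Both measured compounds share one core and differ only in the group on the amine nitrogen in the six-membered non-aromatic ring with 2 nitrogen. In an assay on CHO cells for displacement of a labelled ligand from adenosine receptor A3 (Homo sapiens), read by scintillation counting, with a stated time of 120 min, tested at 10 uM (a lower number here means less inhibition, a higher number more inhibition at the concentration tested (going by the name of the read-out)), compound 1 gives 0%, and in this assay compound 2 gives 0%. Compound 2 therefore stands level with compound 1: the step of no change at the digits printed from compound 1 to compound 2 (within the scatter), in which a much larger aromatic group took the place of a small branched chain, left the read-out where it was.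

Compound 3, `Nc1scc(CN2CCN(c3cccc(F)c3F)CC2)c1C(=O)c1ccc(Cl)cc1`, is the next variation at the same place: 2,3-difluorophenyl in place of naphthalen-1-yl on an amine nitrogen in a ring. Going by the values given here, the one measured step that bears on this position is the one from compound 1 to compound 2, and its size was nil within the scatter. A change from one flat aromatic group on that nitrogen to another, smaller one is therefore not expected to move the read-out noticeably either, and the expected step of a number 3 percentage points higher from compound 2 to compound 3 (within the scatter) is none beyond the scatter. For compound 3 the estimate in this assay is 3%, with a range from 0% to 20%.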

Compound 3, a percentage reported as inhibition, at one concentration (the size of the read-out at that concentration, not a potency): 0%
Compound 3: the middle estimate sits 3 percentage points above what was measured, within the range that was stated.
By their numbers in this assay, from the lowest: compounds 1, 2 and 3 (each within the scatter of the next).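

In this assay, replacing naphthalen-1-yl with 2,3-difluorophenyl, which leaves one six-membered aromatic ring in place of two and adds two fluorine atoms, gives no change at the digits printed from compound 2 to compound 3 (within the scatter). The direct comparison with the small branched chain reads the same, no change at the digits printed from compound 1 to compound 3 (within the scatter), so isopropyl, naphthalen-1-yl and 2,3-difluorophenyl on this amine nitrogen now all give the same printed value, and adding fluorine atoms to the aromatic group is a kind of change the earlier pair did not cover. No measurement here offers an explanation for this flat result.

Since all three values are the same, these compounds show no group on this nitrogen that raises the inhibition, and they cannot show which features of the group matter, if any do. From the compounds shown here alone, whether a benzyl group, a pyridin-2-yl ring or a longer chain ending in an amine would lift the read-out at this nitrogen stays open, as does whether changing the 4-chlorophenyl ketone part of the shared core, for example to a 4-methoxyphenyl ketone, would do so.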